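The source may report more compounds than this note shows. Statements on the series, on what has been measured and on what is new or still open speak of the compounds shown alone.

Measured so far, all in a functional assay on DU-145 cells (Homo sapiens) for inhibition, read by trypan blue exclusion, with a stated time of 96 h; on this read-out higher numbers stand for weaker inhibition of growth and lower numbers for stronger inhibition of growth:
- compound 1 `Cc1ccc(CS(=O)(=O)/C(=C/c2c[nH]c3ccc(Br)cc23)C(=O)c2ccc(Cl)cc2)cc1`: 10000 nM
- compound 2 `COc1cc(OC)c(/C=C(\C(=O)c2ccc(Cl)cc2)S(=O)(=O)Cc2ccc(F)cc2)c(OC)c1`: 25000 nM
- compound 3 `COc1ccsc1/C=C(\C(=O)c1ccc(Br)cc1)S(=O)(=O)Cc1ccc(Cl)cc1`: 50000 nM

Compound 1 gives the lowest number of the three; the numbers of compound 2 and compound 3 both lie beyond the scatter above it, so compound 1 is the strongest inhibitor of growth among the measured set, though all three sit in a weak range.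

Compound 4 `Cc1ccc(CS(=O)(=O)/C(=C/c2cccc(Cl)c2Cl)C(=O)c2ccc(Cl)cc2)cc1` is not yet measured. It differs from compound 1 in one place: 2,3-dichlorophenyl in place of 5-bromo-1H-indol-3-yl on a double-bonded chain carbon bound to a double-bonded chain carbon. Going by the values given here, no measured pair shows this kind of exchange, so its size cannot be read from the set. Given the weak range of the whole series, a small step toward weaker inhibition is expected from compound 1 to compound 4, a 1.6-fold higher number from compound 1 to compound 4 (0.20 log units; within the scatter), or none beyond the scatter. Compound 4 is estimated at 16000 nM, within 5000 nM to 50000 nM.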

Compound 4, concentration for 50% growth inhibition: 1000 nM
Compound 4: middle estimate off by 16-fold (1.20 log units), on the high side; measured number below the stated range.
By their numbers in this assay, from the lowest: compound 4; then compound 1; then compounds 2 and 3 (each within the scatter of the next).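

In this assay, the position on a double-bonded chain carbon bound to a double-bonded chain carbon proves able to carry growth inhibition past the earlier range: 2,3-dichlorophenyl in place of 5-bromo-1H-indol-3-yl gives a 10-fold lower number from compound 1 to compound 4 (1.00 log units; beyond the scatter). The exchange drops the five-membered aromatic ring, the hydrogen-bond donor and the bromine and brings in two chlorines, and this single pair cannot separate these changes. No available evidence bears on the cause of the step.

Going by these compounds, whether the chlorines matter, or the plain six-membered ring alone suffices, stays open. Also open, on these data alone, is how a phenyl bearing an amine or a carboxylic acid would behave at this position.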